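Changing the Aryl Ether Ring: Bromophenyl to Difluorophenyl

The source may report more compounds than this note shows. Statements on the series, on what has been measured and on what is new or still open speak of the compounds shown alone.

Compound 1 `Cc1nnsc1CO/N=C/c1c(C)nn(C)c1Oc1ccc(Br)cc1` gives the lowest number of the three compounds tested in a functional assay on HCT-116 cells (Homo sapiens) for inhibition, read by MTT assay, with a stated time of 48 h (a higher number here means a weaker inhibitor, a lower number a stronger inhibitor), at 7190 nM. Compound 2 `Cc1nnsc1CO/N=C/c1c(C)nn(C)c1Oc1ccc(OC(F)(F)F)cc1` gives 12800 nM, and a 1.8-fold higher number from compound 1 to compound 2 (0.25 log units; within the scatter). Compound 3 `Cc1nnsc1CO/N=C/c1c(C)nn(C)c1Oc1ccc(C(C)(C)C)cc1` gives 33500 nM, and a 4.7-fold higher number from compound 1 to compound 3 (0.67 log units; beyond the scatter); likewise a 2.6-fold higher number from compound 2 to compound 3 (0.42 log units; beyond the scatter). Compound 4 `Cc1nnsc1CO/N=C/c1c(C)nn(C)c1Oc1cccc(F)c1F` differs from compound 1 by 2,3-difluorophenyl in place of 4-bromophenyl on an oxygen on an aromatic ring. Within the data shown here, none of the measured steps tests this change directly: each swapped a single group on one aromatic carbon, whereas here the whole ring is exchanged, and both replacements starting from compound 1 gave higher numbers in this assay. A step of modest size, more likely towards a higher number, is therefore expected. Compound 4 is estimated at 11000 nM, with a range from 3500 nM to 35000 nM. The expected step is a 1.5-fold higher number from compound 1 to compound 4 (0.18 log units; within the scatter).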

Compound 4, half-maximal inhibitory concentration: 6560 nM
Beside the measured number, compound 4's estimate is 1.7-fold (0.22 log units) above it; low and high end bracket the measured number.
By their numbers in this assay, from the lowest: compounds 4, 1 and 2 (each within the scatter of the next); then compound 3.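

In this assay, the exchange of the whole ring gives a 1.1-fold lower number from compound 1 to compound 4 (0.04 log units; within the scatter), so compound 1 and compound 4 cannot be told apart. Bromine is therefore not needed here, and a change of the ring's substituents can leave the number within the scatter, whereas tert-butyl gave a 4.7-fold higher number from compound 1 to compound 3 (0.67 log units; beyond the scatter). No measurement shown here explains this result. Still open, on these data alone, is how a phenyl ring carrying an amine or a carboxylic acid would fare on this oxygen, and whether a saturated ring such as cyclohexyl could replace the aromatic ring altogether.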